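A few compounds are considered here, and "the series" means these few. Any claim that something is new, unique, unknown or untested is made for them only; others in the source may bear on it.

Measured in an ADME assay on cells (Fibroblast, Homo sapiens) for inhibition, read by MTT assay, with a stated time of 24 h; a lower number here means a stronger inhibitor, a higher number a weaker inhibitor:

compound 1 `CCCCOc1ccc(C(=O)N/N=C/c2ccc3c(c2)no[n+]3[O-])cc1`: > 200000 nM
compound 2 `CCCCc1ccc(C(=O)N/N=C/c2ccc3c(c2)no[n+]3[O-])cc1`: > 200000 nM
compound 3 `CC(C)c1ccc(C(=O)N/N=C/c2ccc3c(c2)no[n+]3[O-])cc1`: > 200000 nM

Compound 1 stands at > 200000 nM, which is a limit and not a number. The other two results are limits as well, so the series stands at the limit of > 200000 nM in this assay, at which 3 of the 3 values shown sit, and compound 1 has no readable rank within it.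

The next compound is compound 4 `NS(=O)(=O)c1ccc(C(=O)N/N=C/c2ccc3c(c2)no[n+]3[O-])cc1`, with sulfamoyl in place of butoxy on an aromatic carbon. The measured steps at this same place are a step that the two limits leave unreadable from compound 1 to compound 2, a step that the two limits leave unreadable from compound 1 to compound 3 and a step that the two limits leave unreadable from compound 2 to compound 3. None of them offers a size to carry over, and none involves sulfamoyl. What they do show is that compound 2 and compound 3 both remain at the limit reached by compound 1. No step beyond the scatter is therefore expected in this assay, in either direction, and a further limit is the likeliest report. The expected change is a number no higher from compound 1 to compound 4 (the limit leaves the size open). For compound 4 the estimated value is 200000 nM, with an expected range of 100000 nM to 400000 nM.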

Compound 4, half-maximal inhibitory concentration: 60000 nM
For compound 4 the middle estimate is 3.3-fold (0.52 log units) above the measured one; measured number below the stated range.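

In this assay, within the data shown here, sulfamoyl on an aromatic carbon para to a large group gives the first step at this position that can be read: an at least 3.3-fold lower number from compound 1 to compound 4 (0.52 log units; beyond the scatter) is joined by an at least 3.3-fold lower number from compound 2 to compound 4 (0.52 log units; beyond the scatter) and by an at least 3.3-fold lower number from compound 3 to compound 4 (0.52 log units; beyond the scatter) in the same direction. The position can therefore register a change in this assay, where butoxy, butyl and isopropyl left only limits and the steps among them cannot be read: the limit of > 200000 nM in this assay, at which 3 of the 4 values shown sit. Compound 4 alone carries a number rather than a limit, and each of its three steps lies beyond the scatter.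

As far as these compounds go, how large these steps truly are stays open, as each is measured against a limit. Also open, from the compounds shown here alone, is whether the change is particular to sulfamoyl or would also appear with an amine or a carboxylic acid at this position.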